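Replacing a ring-borne amide with a hydroxy group

The source may hold more compounds than are shown below. What is called first, only, known or untested is meant among the compounds shown, and "the series" means these compounds.

Compound 2 `Cc1nc(N2CCC(C(=O)NC(C)C)CC2)nc2ccc(NC(=O)COc3ccc(Cl)cc3)cc12` is the reference point of this account. In a functional assay on CHO-K1 cells for antagonist activity at melanin-concentrating hormone receptor 1 (Homo sapiens), read by inositol phosphate accumulation (a higher number here means a weaker inhibitor, a lower number a stronger inhibitor), compound 2 gives 25 nM, the lowest number among the three measured compounds; compound 3 `Cc1nc(N2CCN(C(=O)C3CCC3)CC2)nc2ccc(NC(=O)COc3ccc(OC(F)(F)F)cc3)cc12` gives 45 nM, a gap that lies within the scatter, while compound 1 `Cc1nc(N2CCC(NC(=O)C(C)C)CC2)nc2ccc(NC(=O)COc3ccc(Cl)cc3)cc12` gives 54 nM. Among the measured compounds shown here, the only single-point step among them, a 2.2-fold lower number from compound 1 to compound 2 (0.33 log units; beyond the scatter), shows that turning the amide around on the saturated ring carbon shifts the number only modestly.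

Compound 4 `Cc1nc(N2CCC(O)CC2)nc2ccc(NC(=O)COc3ccc(Cl)cc3)cc12` differs from compound 2 by a larger change: hydroxy in place of isopropylcarbamoyl on a saturated ring carbon. For the measured compounds named here, no measured pair removes this group altogether, so the step from compound 1 to compound 2 is the nearest guide, and it tells only that the orientation of the amide matters little. Removing the whole group is expected to cost some potency in this assay, with considerable uncertainty. Compound 4 is therefore estimated to give 100 nM, with a plausible range from 30 nM to 400 nM, corresponding to an expected step of a 4.0-fold higher number from compound 2 to compound 4 (0.60 log units; beyond the scatter).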

Compound 4, half-maximal inhibitory concentration: 163 nM
Compound 4: the middle estimate sits 1.6-fold (0.21 log units) below what was measured, within the range that was stated.
By their numbers in this assay, from the lowest: compounds 2, 3 and 1 (each within the scatter of the next, the first and the last beyond it); then compound 4.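

In this assay, the saturated ring carbon proves more sensitive to losing the amide than to turning it around: a 6.5-fold higher number from compound 2 to compound 4 (0.81 log units; beyond the scatter), whereas reversing the amide gives a 2.2-fold lower number from compound 1 to compound 2 (0.33 log units; beyond the scatter). Measured against the other amide orientation, there is a 3.0-fold higher number from compound 1 to compound 4 (0.48 log units; beyond the scatter), so both amides give lower numbers than the hydroxy group, each by a step beyond the scatter. The hydroxy group matches isopropylcarbamoyl in its counts of hydrogen-bond donors and acceptors, so those counts alone do not separate compound 4 from compound 2.

Nothing shown here accounts for the rise in the number. Still open, from the compounds shown here alone, is how an intermediate group on this carbon, such as a primary carboxamide, an amine or a carboxylic acid, would compare with the hydroxy group and the isopropyl amides.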